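The source may hold more compounds than are shown below. What is called first, only, known or untested is meant among the compounds shown, and "the series" means these compounds.

All numbers in these notes come from a functional assay on HCT-116 cells (Homo sapiens) for inhibition, read by colorimetric assay, with a stated time of 3 days; on this read-out lower numbers stand for stronger inhibition and higher numbers for weaker inhibition. Compound 1 (`O=C(CCCCCCNC(=O)C(O)(O)C(F)(F)F)Nc1ccc(Br)cc1`) gives 3130 nM. Compound 2 (`O=C(CCCCCCNC(=O)C(O)(O)C(F)(F)F)Nc1nc2ccc(Cl)cc2s1`) gives 11000 nM, the higher of the two numbers, which makes it the weaker inhibitor of this pair, with a gap to compound 1 that lies beyond the scatter.

The next entry, compound 3 (`O=C(CCCCCCNC(=O)C(O)(O)C(F)(F)F)Nc1nc2ccc(F)cc2s1`), has not yet been measured. It keeps everything in compound 2 except one substituent: fluoro in place of chloro on an aromatic carbon. In words, this is fluoro in place of chloro on an aromatic carbon, on a six-membered aromatic ring of carbon only that is part of a fused system of two rings.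

Among the compounds with values here, no measured pair isolates this exchange, so the expectation rests only on the structural change and on compound 2 at 11000 nM. The expected step in this assay is small, a 1.2-fold lower number from compound 2 to compound 3 (0.09 log units; within the scatter), which stays within the scatter and leans only slightly toward a lower number. For compound 3 the estimated value is 9000 nM, with an expected range of 4000 nM to 20000 nM.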

Compound 3, half-maximal inhibitory concentration: 6470 nM
Compound 3: the middle estimate sits 1.4-fold (0.14 log units) above what was measured; measured number inside the range.
By their numbers in this assay, from the lowest: compound 1; then compounds 3 and 2 (each within the scatter of the next).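

In this assay, fluoro in place of chloro on an aromatic carbon gives a 1.7-fold lower number from compound 2 to compound 3 (0.23 log units; within the scatter) and so leaves compound 2 and compound 3 within the scatter of each other. Within the data shown here, this is the first step that isolates a single place, and it shows that, on the six-membered aromatic ring of carbon only, this exchange of one halogen for the other does not separate the two compounds in this read-out. No supporting measurement bears on this step, and the data give no reason for its size.

The compounds shown leave open how this same position would read with hydrogen, an amine or a methoxy group, since only chloro and fluoro appear there, so it cannot yet be said whether the substituent at this place matters at all. Also open, going by these compounds, is whether a longer chain or a carboxylic acid elsewhere on the shared core would move the number more than this halogen exchange does.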